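From oxadiazole to methylimidazole on the shared core

The compounds below may be only part of what the source reports. "The series", "measured", "known", "first", "only" and "open" are said of these compounds alone.

Going by the values given here, in an in vivo ADME assay on the whole organism (strain 129/SvEvBrd x C57BL/6) for pharmacokinetics, with Mus musculus as the target (a higher number here means that a larger share of the oral dose reaches the circulation, a lower number that a smaller share of the oral dose reaches the circulation), compound 2 `OC[C@@H](O)[C@@H](O)[C@H](O)c1c[nH]c(-c2ncon2)n1` gives 5%, the lower of the two numbers so far, while compound 1 `OC[C@@H](O)[C@@H](O)[C@H](O)c1c[nH]c(-c2ncc[nH]2)n1` gives 28%. The unmeasured compound 3 `Cn1cnc(-c2nc([C@@H](O)[C@H](O)[C@H](O)CO)c[nH]2)c1` differs from compound 2 in one place: 1-methyl-1H-imidazol-4-yl in place of 1,2,4-oxadiazol-3-yl on an aromatic carbon. Among the compounds with values here, the one measured step that bears on this is a number 23 percentage points lower from compound 1 to compound 2 (beyond the scatter). It suggests that an imidazole group at this place may recover part of that loss, though this imidazole is a different one. The expected change is upward, an estimated a number 13 percentage points higher from compound 2 to compound 3 (beyond the scatter). For compound 3 the estimated value is 18%, within a range of 6% to 35%.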

Compound 3, oral bioavailability: 3%
Compound 3: the middle estimate sits 15 percentage points above what was measured; measured number below the stated range.
By their numbers in this assay, from the lowest: compounds 3 and 2 (each within the scatter of the next); then compound 1.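

Having an imidazole at this place is not enough by itself: 1-methyl-1H-imidazol-4-yl in place of 1,2,4-oxadiazol-3-yl gives a number 2 percentage points lower from compound 2 to compound 3 (within the scatter), and in place of 1H-imidazol-2-yl it gives a number 25 percentage points lower from compound 1 to compound 3 (beyond the scatter). Of these three groups, only 1H-imidazol-2-yl stands apart in oral bioavailability. Nothing measured here explains why. Still open, as far as these compounds go, is how a simple amine or a carboxylic acid on this aromatic carbon would compare, and whether any group here could surpass the 1H-imidazol-2-yl of compound 1.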